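Trimming the (2-methylphenyl)carbonyl group of compound 2

The source may report more compounds than this note shows. Statements on the series, on what has been measured and on what is new or still open speak of the compounds shown alone.

Compound 2 `Cc1ccccc1C(=O)c1ccc2c(c1)C(n1ccccc1=O)=CC(C)(C)O2` gives 6.25 in a functional assay (trachea) with Rattus norvegicus as the target; on this read-out higher numbers stand for higher potency (the scale is a negative logarithm) and lower numbers for lower potency. It stands within the scatter of compound 1 `CC1(C)C=C(n2ccccc2=O)c2cc(C(=O)c3ccccc3F)ccc2O1`, which gives 6.34 in this assay, the two numbers set apart only by a number 0.09 log units lower from compound 1 to compound 2 (within the scatter). Compound 3 `CC1(C)C=C(n2ccccc2=O)c2cc(C(=N)NO)ccc2O1` is not yet measured; relative to compound 2 the change is a group of 4 heavy atoms (1 carbon, 2 nitrogen, 1 oxygen; no ring) in place of a group of 9 heavy atoms (8 carbon, 1 oxygen; one six-membered aromatic ring of carbon only), on an aromatic carbon. Within the data shown here, no measured step covers such a replacement: the single step known touches only a substituent on the ring that now leaves, so it gives no guide to size or direction. The step is expected to be a drop beyond the scatter, a number 0.75 log units lower from compound 2 to compound 3 (beyond the scatter). Compound 3 is estimated at 5.5, range 4.6 to 6.4.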

Compound 3, logarithm of the reciprocal of the active concentration, log(1/C): 5.51
Estimate against measurement, compound 3: 0.01 log units below, within the range that was stated.
By their numbers in this assay, from the lowest: compound 3; then compounds 2 and 1 (each within the scatter of the next).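

In this assay, among these compounds, this aromatic carbon is the first place where a change moves the number beyond the scatter: the ring-free group in place of (2-methylphenyl)carbonyl gives a number 0.74 log units lower from compound 2 to compound 3 (beyond the scatter), and in place of the fluorinated aryl carbonyl gives a number 0.83 log units lower from compound 1 to compound 3 (beyond the scatter). Both drops are modest, so the aromatic ring of the leaving group is not required for a measurable read-out. Nothing measured here explains the drop.

The compounds shown do not separate loss of the aromatic ring from loss of the carbonyl or from the entering group itself. On these data alone, how an acetyl group, a carboxylic acid or a primary amine would read at this aromatic carbon also stays open.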